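A side-chain swap in a level series

This account rests on a few compounds, and the source may have more. Where it says the series, first, only, none or still open, it means among the compounds named here.

In a functional assay on U-87MG ATCC cells for cytotoxicity against U-87 MG (Homo sapiens), read by colorimetric assay and MTT assay (on this read-out lower numbers stand for stronger inhibition and higher numbers for weaker inhibition), compound 1 `COc1ccc2cc(-c3ccccc3)c(O)nc2c1` gives 10000 nM, compound 2 `COc1cc(OC)c2cc(-c3ccccc3)c(O)nc2c1` gives 10000 nM and compound 3 `CCN(CC)C(=O)Cn1c(=O)c(-c2ccc(OC)cc2)cc2c(OC)cc(OC)cc21` gives 10000 nM, so compound 3 stands level with both. Compound 4 `COc1ccc(-c2cc3c(OC)cc(OC)cc3n(CCC#N)c2=O)cc1` differs from compound 3 by cyanomethyl in place of diethylcarbamoyl on a saturated chain carbon bound to an aromatic nitrogen, with cyanomethyl in place of diethylcarbamoyl on a saturated chain carbon bound to an aromatic nitrogen. Within the data shown here, the only measured step, no change at the digits printed from compound 1 to compound 2 (within the scatter), is a different change, methoxy in place of hydrogen on an aromatic carbon, and it stays within the scatter. Among the measured compounds shown here, no measured step covers this swap, so the evidence is indirect. The step expected in this assay is no change at the digits printed from compound 3 to compound 4 (within the scatter), with none beyond the scatter. Compound 4 is expected at 10000 nM, with an estimated range of 4000 nM to 20000 nM.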

Compound 4, half-maximal inhibitory concentration: 10000 nM
Compound 4: the middle estimate sits on the measured number at the digits printed; measured number inside the range.
By their numbers in this assay, from the lowest: compounds 1, 2, 3 and 4 (each within the scatter of the next).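

In this assay, among these compounds, the first measured change on a saturated chain carbon bound to an aromatic nitrogen, cyanomethyl in place of diethylcarbamoyl, gives no change at the digits printed from compound 3 to compound 4 (within the scatter). The earlier step concerned only methoxy on an aromatic carbon, whereas this one shows that replacing a group of 7 heavy atoms with one of 3 leaves the printed value unmoved. Nothing available explains this result. Going by these compounds, whether an amine or a carboxylic acid at this place would separate from the level series remains open, and so does the effect of a longer chain.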